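Bromo to Nitrooxy on the Amide Chain: An Estimate

The compounds below may be only part of what the source reports. "The series", "measured", "known", "first", "only" and "open" are said of these compounds alone.

Of the compounds shown here, three have been measured in a functional assay on the whole organism (strain albino) for inhibition, with Rattus norvegicus as the target, read by paw edema, with stated times of 30 min and 4 h, at a dose of 100 mg/kg by the oral route; a lower number here means less inhibition, a higher number more inhibition at the dose given (going by the name of the read-out). Compound 1 `Nc1ccc(C(=O)/C=C/c2ccc(Cl)cc2)cc1` gives 58%. Compound 2 `O=C(CBr)Nc1ccc(C(=O)/C=C/c2ccc(Cl)cc2)cc1` gives 59%, and compound 3 `O=C(CBr)Nc1ccc(C(=O)/C=C/c2ccco2)cc1` gives 33%. Compound 2 holds the highest of the three numbers, though compound 1 lies within the scatter of it: a number 1 percentage points higher from compound 1 to compound 2 (within the scatter). The one clear difference is a number 26 percentage points lower from compound 2 to compound 3 (beyond the scatter).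

Compound 4 `O=C(CO[N+](=O)[O-])Nc1ccc(C(=O)/C=C/c2ccc(Cl)cc2)cc1` has not yet been measured. It differs from compound 2 in a single place: nitrooxy in place of bromo on a saturated chain carbon bound to a carbonyl carbon.

Among the compounds with values here, no measured step touches this saturated chain carbon, so none bears on it directly. The nearest guide is the step that put the whole (bromomethyl)carbonyl group onto the ring nitrogen, a number 1 percentage points higher from compound 1 to compound 2 (within the scatter), which stayed within the scatter; a change at the far end of that same group therefore seems unlikely to move the number far. Within the data shown here, the only large step, a number 26 percentage points lower from compound 2 to compound 3 (beyond the scatter), arose at the other end of the shared core and says nothing about this position. Compound 4 is therefore expected to give about 58% in this assay, with a range from 42% to 72%, a step of a number 1 percentage points lower from compound 2 to compound 4 (within the scatter) that is expected to remain within the scatter.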

Compound 4, a percentage reported as inhibition, in the whole organism at one dose (the size of the read-out at that dose, not a potency): 67%
For compound 4 the middle estimate is 9 percentage points below the measured one; the measured number falls inside the stated range.
By their numbers in this assay, from the lowest: compound 3; then compounds 1, 2 and 4 (each within the scatter of the next).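

In this assay the saturated chain carbon bound to a carbonyl carbon now has a step of its own: exchanging bromo (1 heavy atom, 0 hydrogen-bond acceptors) for nitrooxy (4 heavy atoms, 3 hydrogen-bond acceptors) gives a number 8 percentage points higher from compound 2 to compound 4 (within the scatter) and so does not separate the two groups at this dose. The full ((nitrooxy)methyl)carbonyl group, set in place of hydrogen on the nitrogen on the aromatic ring, gives a number 9 percentage points higher from compound 1 to compound 4 (within the scatter) and so is not told apart from the free amine compound either, which shows that this position accepts two quite different end groups without a change beyond the scatter. Nothing in the data shown explains these numbers.

As far as these compounds go, whether an amine or a carboxylic acid on this chain carbon, or a longer chain carrying nitrooxy, would also hold the number in this range stays open. Also open, from the compounds shown here alone, is whether nitrooxy in place of bromo would shift the number in the furan-2-yl series, where compound 3 gives 33% and the read-out has more room to rise than in the 4-chlorophenyl series.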